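Adding a Second Chlorine and the Paw Edema Number

This account rests on a few compounds, and the source may have more. Where it says the series, first, only, none or still open, it means among the compounds named here.

Three compounds that share one core were tested in a functional assay on the whole organism (strain Wister albino) for inhibition, with Rattus norvegicus as the target, read by paw edema, with stated times of 1 h and 4 h, at a dose of 50 mg/kg by the intraperitoneal route; a lower number here means less inhibition, a higher number more inhibition at the dose given (going by the name of the read-out). Compound 1 `CCOC(=O)c1c(-c2ccc(Cl)c(Cl)c2)cc(-c2ccccc2)nc1N1CCCCC1` gives 95.1%. Compound 2 `CCOC(=O)c1c(-c2ccc(Cl)cc2)cc(-c2ccccc2)nc1N1CCN(C)CC1` gives 55.6%. Compound 3 `CCOC(=O)c1c(-c2ccc(Cl)cc2)cc(-c2ccccc2)nc1Nc1ccc(C)cc1` gives 90.9%, the second highest of the three numbers; its gap to compound 1 lies within the scatter, while its gap to compound 2 lies beyond it. Among the compounds with values here, the only measured step between two compounds that differ in one place is a number 35.3 percentage points higher from compound 2 to compound 3 (beyond the scatter), and that step concerns the group on the amine side of the core, not the chlorinated ring.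

Compound 4 `CCOC(=O)c1c(-c2ccc(Cl)c(Cl)c2)cc(-c2ccccc2)nc1Nc1ccc(C)cc1` has not yet been measured. It differs from compound 3 by chloro in place of hydrogen on an aromatic carbon, so the 4-chlorophenyl becomes a 3,4-dichlorophenyl. Within the data shown here, no measured step covers exactly this change. The nearest hint comes from compound 1, which already carries the 3,4-dichlorophenyl together with a different amine and gives a number within the scatter of compound 3 in this assay. On that basis no step beyond the scatter is expected, and the estimated step from compound 3 is a number 1.1 percentage points higher from compound 3 to compound 4 (within the scatter). The expected value for compound 4 is therefore 92%, with a likely range from 80% to 99%.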

Compound 4, a percentage reported as inhibition, in the whole organism at one dose (the size of the read-out at that dose, not a potency): 87.9%
Beside the measured number, compound 4's estimate is 4.1 percentage points above it, within the range that was stated.
By their numbers in this assay, from the lowest: compound 2; then compounds 4, 3 and 1 (each within the scatter of the next).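

The direct step for this change, with the (4-methylphenyl)amino group held fixed in this assay, is a number 3 percentage points lower from compound 3 to compound 4 (within the scatter): a chloro ortho to a chloro group gives a number that cannot be told apart from that of the 4-chlorophenyl compound. Within the data shown here, the second new step, a number 7.2 percentage points lower from compound 1 to compound 4 (within the scatter), shows that with the 3,4-dichlorophenyl in place, the (4-methylphenyl)amino and piperidin-1-yl groups cannot be told apart either, while the only earlier step between amines, a number 35.3 percentage points higher from compound 2 to compound 3 (beyond the scatter), was a large one and concerned 4-methylpiperazin-1-yl on the 4-chlorophenyl compounds. Nothing measured here offers a reason for either of these small steps.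

Going by these compounds, it stays open whether the second chloro would matter with 4-methylpiperazin-1-yl, the amine of compound 2 at 55.6%, since the compounds that now carry the 3,4-dichlorophenyl all sit near the top of the scale at this single dose. On these data alone, it also stays open whether a methoxy or a trifluoromethyl in that same place, or a carboxylic acid in place of the ethyl ester, would read any differently.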